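The compounds below may be only part of what the source reports. "The series", "measured", "known", "first", "only" and "open" are said of these compounds alone.

In a physicochemical assay for solubility, read by HPLC, in phosphate buffer, measured as kinetic solubility, at pH 7.4 (a lower number here means a less soluble compound, a higher number a more soluble compound), compound 3 (`CCOC(=O)c1cc(-c2ccc(F)cc2)n(-c2ccc(S(N)(=O)=O)cc2)c1C`) gives 12600 nM. Compound 2 (`CCC(=O)c1cc(-c2cccc(Cl)c2)n(-c2ccc(S(N)(=O)=O)cc2)c1C`) stands level with it at 12600 nM, and compound 1 (`CCOC(=O)c1cc(-c2ccc(Cl)cc2)n(-c2ccc(S(N)(=O)=O)cc2)c1C`) lies lower at 4200 nM. Compound 3 therefore shares the top of the three numbers with compound 2. Compound 4 (`CCOC(=O)c1cc(-c2cccc(Cl)c2)n(-c2ccc(S(N)(=O)=O)cc2)c1C`) is still unmeasured. It carries 3-chlorophenyl in place of 4-fluorophenyl on an aromatic carbon, next to the ring nitrogen: 3-chlorophenyl in place of 4-fluorophenyl on an aromatic carbon.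

For the measured compounds named here, the only measured step that bears directly on this change is a 3.0-fold higher number from compound 1 to compound 3 (0.48 log units; beyond the scatter), a modest step in which fluoro took the place of chloro on an aromatic carbon while the ethoxycarbonyl group stayed. Taken in reverse, it points to a lower number for compound 4, although compound 1 does not carry the 3-chlorophenyl group. Compound 2 does carry that group and still gives 12600 nM, which goes against any simple penalty for chlorine, but it lacks the ethoxycarbonyl group. Going by the values given here, no measured pair isolates the change, so a smaller move than the measured one is expected, in the same downward direction. The expected step is a 1.9-fold lower number from compound 3 to compound 4 (0.29 log units; within the scatter). For compound 4 the estimate is 6500 nM, with an expected range from 3000 nM to 14000 nM.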

Compound 4, solubility: 9200 nM
Compound 4: middle estimate off by 1.4-fold (0.15 log units), on the low side, within the range that was stated.
By their numbers in this assay, from the lowest: compound 1; then compounds 4, 2 and 3 (each within the scatter of the next).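

In this assay, putting 3-chlorophenyl in place of 4-fluorophenyl on this aromatic carbon, next to the ring nitrogen, gives a 1.4-fold lower number from compound 3 to compound 4 (0.14 log units; within the scatter) with the ethoxycarbonyl group kept, so the two groups cannot be told apart at this position on these numbers. For the compounds shown here, compound 1 and compound 4 are the first pair to hold chlorine on both sides, and 3-chlorophenyl in place of 4-chlorophenyl gives a 2.2-fold higher number from compound 1 to compound 4 (0.34 log units; beyond the scatter) so that chlorine on this group does not by itself carry the number down to that of compound 1. With 3-chlorophenyl held fixed, ethoxy in place of ethyl on the carbonyl carbon gives a 1.4-fold lower number from compound 2 to compound 4 (0.14 log units; within the scatter) and so that exchange also stays inside the usual spread of repeated measurements.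

The compounds shown leave open how 3-fluorophenyl, or a phenyl group carrying an amine or a carboxylic acid, would read at this position in this assay, and whether a longer chain in place of ethoxy would keep the number where it is. Nothing measured here gives a reason for any of these steps.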